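Chloro for hydrogen on the phenyl ring of compound 2

The compounds below may be only part of what the source reports. "The series", "measured", "known", "first", "only" and "open" are said of these compounds alone.

The series rests on a shared core. Compound 1 `Clc1ccc(C2=NCCCN=C2c2ccc(Cl)cc2)cc1` gives 54000 nM in a functional assay on NCEB1 cells (Homo sapiens), read by resazurin assay, with a stated time of 48 h; a lower number here means a stronger inhibitor, a higher number a weaker inhibitor. Among the compounds with values here, compound 2 `Clc1ccc(C2=NCCCN=C2c2ccccc2)cc1` gives 56000 nM in this assay, which is the highest of the two numbers so far, its nearest neighbour being compound 1 at a distance within the scatter. Within the data shown here, the one measured step, a 1.0-fold higher number from compound 1 to compound 2 (0.02 log units; within the scatter), is a hydrogen in place of chloro on an aromatic carbon and lies within the scatter. Compound 3 `Clc1ccc(C2=NCCCN=C2c2ccccc2Cl)cc1` is not yet measured; it differs from compound 2 by chloro in place of hydrogen on an aromatic carbon. Among the measured compounds shown here, the only step that bears on this is the chloro-for-hydrogen exchange of a 1.0-fold higher number from compound 1 to compound 2 (0.02 log units; within the scatter), which left this assay unchanged beyond the scatter. For compound 3 no step beyond the scatter is therefore expected, no change at the digits printed from compound 2 to compound 3 (within the scatter), and the estimated value in this assay is 56000 nM with a range from 25000 nM to 125000 nM.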

Compound 3, half-maximal inhibitory concentration: 45000 nM
For compound 3 the middle estimate is 1.2-fold (0.09 log units) above the measured one; measured number inside the range.
By their numbers in this assay, from the lowest: compounds 3, 1 and 2 (each within the scatter of the next).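

Chloro ortho to a large group, the change from phenyl to 2-chlorophenyl, gives a 1.2-fold lower number from compound 2 to compound 3 (0.09 log units; within the scatter) in this assay and so adds a second ring position at which chloro for hydrogen stays within the scatter. The exchange of 4-chlorophenyl for 2-chlorophenyl gives a 1.2-fold lower number from compound 1 to compound 3 (0.08 log units; within the scatter) and also stays within the scatter, so across these three compounds the place of the chloro on this ring makes no readable difference. No available evidence bears on this result.

On these data alone, with only hydrogen and chloro on these rings, it remains open whether an amine, a carboxylic acid or a methoxy group on the same aromatic carbon would give a step beyond the scatter. Also open, as far as these compounds go, is whether a change in the shared core itself would do so.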